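The source may hold more compounds than are shown below. What is called first, only, known or untested is meant among the compounds shown, and "the series" means these compounds.

Within the data shown here, the two compounds measured so far share one core. Compound 1 `N=C(NCc1ccccc1)[C@@H]1CCC(=O)N1Cc1ccccc1` gives 16.6% in a functional assay on SH-SY5Y cells (Homo sapiens) for cytotoxicity, read by MTT assay, with stated times of 8 h, 30 min and 12 h, tested at 0.05 uM; a higher number here means a stronger effect of the compound at the concentration tested, a lower number a weaker effect. Compound 2 `N=C(NCc1ccc(O)cc1)[C@@H]1CCC(=O)N1Cc1ccccc1`, which carries a hydroxy in place of hydrogen on an aromatic carbon, gives 19.8% in this assay; the step of a number 3.2 percentage points higher from compound 1 to compound 2 (within the scatter) is within the scatter. Among the measured compounds shown here, of the two numbers, the one for compound 2 is the larger, but the gap to compound 1 is within the scatter, so the two cannot be told apart.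

Compound 3 `COc1ccc(CNC(=N)[C@@H]2CCC(=O)N2Cc2ccccc2)cc1` has not yet been measured. It differs from compound 2 in one place: methyl in place of hydrogen on an oxygen on an aromatic ring. For the measured compounds named here, no measured step tests this change directly. Going by the values given here, the only step available, a number 3.2 percentage points higher from compound 1 to compound 2 (within the scatter), alters the same aromatic ring and left the read-out essentially unchanged, which gives no reason to expect a shift beyond the scatter here, though a single step is thin ground for the next. Compound 3 is therefore expected to show a step of a number 1.8 percentage points lower from compound 2 to compound 3 (within the scatter), that is, none beyond the scatter. The estimate for compound 3 is 18%, with a range from 9% to 28%.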

Compound 3, a percentage reported as activity, at one concentration (the size of the read-out at that concentration, not a potency): 7.1%
Beside the measured number, compound 3's estimate is 10.9 percentage points above it, outside the stated range (below it).
By their numbers in this assay, from the lowest: compounds 3, 1 and 2 (each within the scatter of the next, the first and the last beyond it).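

On the oxygen on the aromatic ring, methyl in place of hydrogen gives a number 12.7 percentage points lower from compound 2 to compound 3 (beyond the scatter) in this assay and is the only step among those shown that lies beyond the scatter, so this position responds to a small change in a way the hydroxy step alone had not revealed. Measured directly against compound 1, the added methoxy group gives a number 9.5 percentage points lower from compound 1 to compound 3 (within the scatter) and therefore cannot be told apart from the compound lacking the group, so the effect appears only in the comparison between the hydroxy and methoxy compounds. Nothing available accounts for why adding this one methyl to the hydroxy group gives a step of this size.

Going by these compounds, whether a longer chain on the same oxygen, such as ethyl, would continue the direction of the methyl step remains open, as does the outcome of replacing the hydroxy with an amine or a carboxylic acid. All three compounds vary only at this aromatic ring and are read at a single concentration, so they say nothing about changes elsewhere on the shared core or about behaviour at other concentrations.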